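Swapping the Sulfamoyl of Compound 1 for Acetamido

A few compounds are considered here, and "the series" means these few. Any claim that something is new, unique, unknown or untested is made for them only; others in the source may bear on it.

Measured compounds:
compound 1 `CC(C)(C)c1ccc(C(=O)NCc2ccc(S(N)(=O)=O)cc2)cc1` gives 1400 nM in an assay on HeLa cells with Bile acid receptor (Homo sapiens) as the target, read by a luciferase reporter, with a stated time of 24 h; a higher number here means that more compound is needed for the effect, a lower number that less compound is needed
compound 2 `O=C(O)c1ccc(CNC(=O)c2ccc3ccccc3c2)cc1` gives 1360 nM
compound 3 `CC(C)(C)c1ccc(C(=O)NCc2ccc(C(=O)O)cc2F)cc1` gives 7.8 nM

Among the three measured compounds, compound 1 has the highest number in this assay. Among the compounds with values here, compound 2 lies nearest, with a number that is within the scatter of the one for compound 1, so the two cannot be told apart. Compound 3 stands furthest away, with a number far lower than that of compound 1, a gap well beyond the scatter.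

Compound 4 `CC(=O)Nc1ccc(CNC(=O)c2ccc(C(C)(C)C)cc2)cc1` has not yet been measured. It differs from compound 1 in a single place: acetamido in place of sulfamoyl on an aromatic carbon. Within the data shown here, no pair of measured compounds shows a change of this kind, so nothing in the present data tells how large a step to expect. In this assay the estimated step of a 1.8-fold higher number from compound 1 to compound 4 (0.25 log units; within the scatter) is small and is expected to stay within or only slightly beyond the scatter, leaning toward a higher number. The number for compound 4 is therefore expected at 2500 nM, with a range from 700 nM to 9000 nM.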

Compound 4, half-maximal effective concentration: 2900 nM
Compound 4: the middle estimate sits 1.2-fold (0.06 log units) below what was measured; low and high end bracket the measured number.
By their numbers in this assay, from the lowest: compound 3; then compounds 2 and 1 (each within the scatter of the next); then compound 4.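

In this assay, within the data shown here, putting acetamido in place of sulfamoyl on this aromatic carbon, para to a large group, gives a 2.1-fold higher number from compound 1 to compound 4 (0.32 log units; beyond the scatter), the first step that can be read at this position. Both groups hold 4 heavy atoms and neither carries a net charge, yet the number still moves modestly, so an exchange of this kind at this carbon is not neutral. Nothing measured here bears on why the number moves.

The compounds shown leave open how an amine or a carboxylic acid alone at this same carbon would read on the core of compound 1. Compound 3 differs from compound 1 in more than one place, so its far lower number cannot be tied to any single change.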